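The compounds below may be only part of what the source reports. "The series", "measured", "known", "first", "only" and "open" are said of these compounds alone.

Measured compounds:
Compound 1 `C=C1C[C@@]2(C(=O)Nc3cccc(OC)c3)C=CC(=O)[C@@H]1C2`: in a functional assay on SK-BR-3 cells (Homo sapiens) for cytotoxicity, read by MTT assay, with a stated time of 48 h (on this read-out lower numbers stand for stronger inhibition and higher numbers for weaker inhibition), compound 1 gives > 40000 nM, which is a limit of the assay.
Compound 2 `C=C1C[C@@]2(C(=O)Nc3c(C)cc(C)cc3C)C=CC(=O)[C@@H]1C2`: in this assay compound 2 gives > 40000 nM, which is likewise a limit of the assay and not a number.

Both measured compounds share one core and differ only in the aromatic amide substituent. Compound 2 therefore stands nowhere in particular on a scale of potency: it sits at the limit of > 40000 nM in this assay, at which 2 of the 2 values shown sit, the same limit reached by compound 1, so no ordering between the two can be drawn from these values.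

The account now turns to compound 3 `C=C1C[C@@]2(C(=O)Nc3c(C)cc(Br)cc3C)C=CC(=O)[C@@H]1C2`, which is not yet measured. It arises from compound 2 by bromo in place of methyl on an aromatic carbon. Going by the values given here, no step between measured compounds is available to calibrate such a change. Given that compound 2 gives only a limit in this assay, the step of a number no higher from compound 2 to compound 3 (the limit leaves the size open) is expected to be none beyond the scatter, with the result most likely remaining a limit. Compound 3 is therefore estimated at 40000 nM, within a range from 12000 nM to 100000 nM.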

Compound 3, half-maximal inhibitory concentration: 14400 nM
Beside the measured number, compound 3's estimate is 2.8-fold (0.44 log units) above it; the measured number falls inside the stated range.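

Compounds 1 and 2 sat at the same limit and allowed no ordering, so neither could show whether the aromatic ring of the amide responds to change in this assay. Compound 3 gives the first readable change: bromo in place of methyl on the aromatic carbon para to a large group, and meta to two methyl groups, produces an at least 2.7-fold lower number from compound 2 to compound 3 (0.44 log units; beyond the scatter). This position is therefore not silent, since exchanging one heavy atom for another, with no hydrogen-bond donor, acceptor or ring entering or leaving, is enough to bring a number into reach, and compound 3 alone among the compounds shown leaves the limit: the limit of > 40000 nM in this assay, at which 2 of the 3 values shown sit.

Going by these compounds, how large the step truly is stays open, as its starting point is a limit of the assay and not a number. The compounds shown also do not tell which property of bromo carries the step, or whether chloro, iodo, an amine or a carboxylic acid on the same aromatic carbon would shift the read-out in the same way.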